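Replacing the 4-methoxyphenyl of compound 2 with methyl

This account rests on a few compounds, and the source may have more. Where it says the series, first, only, none or still open, it means among the compounds named here.

Measured in a functional assay on A549 cells (Homo sapiens) for inhibition, read by MTT assay, with a stated time of 72 h; on this read-out higher numbers stand for weaker inhibition and lower numbers for stronger inhibition:
- compound 1 `Cc1ccc(-c2cc(C(=O)N3CCC4(CC3)CC(=O)c3nn(C(C)(C)C)cc3O4)c3ccccc3n2)cc1`: 5300 nM
- compound 2 `COc1ccc(-c2cc(C(=O)N3CCC4(CC3)CC(=O)c3nn(C(C)(C)C)cc3O4)c3ccccc3n2)cc1`: 3740 nM
- compound 3 `CC(C)(C)n1cc2c(n1)C(=O)CC1(CCN(C(=O)c3cc(-c4ccccn4)nc4ccccc34)CC1)O2`: 7720 nM

Compound 2 stands at the low end of these values, but not alone: the record shows a 1.4-fold lower number from compound 1 to compound 2 (0.15 log units; within the scatter). Compound 4 `Cc1cc(C(=O)N2CCC3(CC2)CC(=O)c2nn(C(C)(C)C)cc2O3)c2ccccc2n1` carries methyl in place of 4-methoxyphenyl on an aromatic carbon. At that carbon, the swaps measured so far exchange one aromatic ring for another, and they stay small: a 2.1-fold higher number from compound 2 to compound 3 (0.31 log units; beyond the scatter), and a 1.5-fold higher number from compound 1 to compound 3 (0.16 log units; within the scatter). For the measured compounds named here, no measured compound lacks the ring there, so these steps guide the direction only loosely. The expected result in this assay is a 3.2-fold higher number from compound 2 to compound 4 (0.51 log units; beyond the scatter), somewhat larger than those steps. The estimated value for compound 4 is 12000 nM, with an expected range from 5000 nM to 30000 nM.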

Compound 4, half-maximal inhibitory concentration: > 10000 nM
Compound 4 gave a limit, no number; the forecaster's own chance of this, stated with the estimate: 15%; the middle value is on the limit's open side.
By their numbers in this assay, from the lowest: compounds 2, 1 and 3 (each within the scatter of the next, the first and the last beyond it). At a limit, above all of these: compound 4.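

Compound 4 gives a limit and not a number in this assay: the limit of > 10000 nM in this assay, at which 1 of the 4 values shown sits.

For the compounds shown here, it is the first compound here with no aromatic ring at this carbon, where methyl stands instead. Only an at least 2.6-fold higher number from compound 2 to compound 4 (0.42 log units; beyond the scatter) clears the scatter, whereas an at least 1.8-fold higher number from compound 1 to compound 4 (0.27 log units; that floor lies within the scatter) and an at least 1.2-fold higher number from compound 3 to compound 4 (0.11 log units; that floor lies within the scatter) leave compound 4 not clearly separated from those two compounds.

As far as these compounds go, how far the number rises once the ring is gone remains open, since the limit gives no upper end. Also open, from the compounds shown here alone, is whether an amine or a longer alkyl chain at this carbon would behave like methyl or like the aromatic rings.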